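From isopropyl(methyl)amino to piperidin-1-yl

The source may hold more compounds than are shown below. What is called first, only, known or untested is meant among the compounds shown, and "the series" means these compounds.

In a functional assay on the whole organism with Rattus norvegicus as the target (on this read-out higher numbers stand for an effect only at larger amounts of compound and lower numbers for an effect already at smaller amounts), compound 1 `CCNc1cccc(NC(=O)C(=O)OCC)c1C#N` gives 0.03 mg/kg. Compound 2 `CCOC(=O)C(=O)Nc1cccc(N(C)CC)c1C#N` gives 0.3 mg/kg, and compound 3 `CCOC(=O)C(=O)Nc1cccc(N(C)C(C)C)c1C#N` gives 0.3 mg/kg. Compound 3 therefore stands level with compound 2, the two together holding the highest of the three numbers.

Compound 4 `CCOC(=O)C(=O)Nc1cccc(N2CCCCC2)c1C#N` has piperidin-1-yl in place of isopropyl(methyl)amino on an aromatic carbon, ortho to a cyano group: piperidin-1-yl in place of isopropyl(methyl)amino on an aromatic carbon. Going by the values given here, no measured compound has a ring at this place, so the data offer no direct precedent. The larger steps, a 10-fold higher number from compound 1 to compound 2 (1.00 log units; beyond the scatter) and a 10-fold higher number from compound 1 to compound 3 (1.00 log units; beyond the scatter), both lead away from the ethylamino group to a fully substituted nitrogen. The step that keeps such a nitrogen, no change at the digits printed from compound 2 to compound 3 (within the scatter), stayed within the scatter, and that is the closest guide here. With a fully substituted nitrogen retained, the expected outcome is no change at the digits printed from compound 3 to compound 4 (within the scatter), and no step beyond the scatter is anticipated in this assay. Compound 4 is estimated at 0.3 mg/kg, with an expected range of 0.1 mg/kg to 1 mg/kg.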

Compound 4, dose for half-maximal effect: 2.2 mg/kg
Compound 4: middle estimate off by 7.3-fold (0.87 log units), on the low side, outside the stated range (above it).
By their numbers in this assay, from the lowest: compound 1; then compounds 2 and 3 (each within the scatter of the next); then compound 4.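

In this assay the piperidin-1-yl ring did not behave like the open-chain groups on this aromatic carbon: a 7.3-fold higher number from compound 3 to compound 4 (0.87 log units; beyond the scatter) and a 7.3-fold higher number from compound 2 to compound 4 (0.87 log units; beyond the scatter) both lie beyond the scatter, whereas the step between the two open-chain groups stayed within it. A fully substituted nitrogen at this place therefore does not by itself set the number, and against the ethylamino group the change reaches a 73-fold higher number from compound 1 to compound 4 (1.87 log units; beyond the scatter), the largest step in the set. Nothing available here accounts for the difference between the ring and the open-chain groups.

The compounds shown leave open whether a smaller ring such as pyrrolidin-1-yl, or morpholin-4-yl with its ring oxygen, would stand with piperidin-1-yl or with the open-chain groups. They also leave open where a plain amino group or a methylamino group would fall relative to ethylamino.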